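A few compounds are considered here, and "the series" means these few. Any claim that something is new, unique, unknown or untested is made for them only; others in the source may bear on it.

Series notes. Going by the values given here, compound 1 `COC(=O)c1ccc(NCc2cncn2Cc2ccc(Cl)cc2)cc1-c1ccccc1` is the only member with a number in a toxicity assay on NIH3T3 cells (Mus musculus) for cytotoxicity, read by resazurin assay; a higher number here means that more compound is needed for the effect, a lower number that less compound is needed: compound 1 gives 25000 nM. Compound 2 `O=C(c1ccc(NCc2cncn2Cc2ccc(-c3ccccc3)cc2)cc1-c1ccccc1)N1CCCCC1` is reported in this assay only as a limit, > 1000 nM. Compound 3 `CNC(=O)c1ccc(NCc2cncn2Cc2ccc(-c3ccccc3)cc2)cc1-c1ccccc1` likewise stands in this assay at a limit, > 1000 nM. Among the compounds with values here, the one step among the measured compounds, a step that the two limits leave unreadable from compound 2 to compound 3, is therefore not readable in size or direction, and the limit of > 1000 nM in this assay, at which 2 of the 3 values shown sit, is where two of the three values sit.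

Compound 4 `COC(=O)c1ccc(NCc2cncn2Cc2cccc(C)c2)cc1-c1ccccc1` differs from compound 1 in one place: 3-methylphenyl in place of 4-chlorophenyl on a saturated chain carbon bound to an aromatic nitrogen. Within the data shown here, no measured step touches this part of the structure; the only step, from compound 2 to compound 3, lies at the carbonyl carbon and is unreadable in any case, so nothing here argues for a move in this assay beyond the scatter in either direction. Resting on compound 1 at 25000 nM, compound 4 is expected in this assay at 25000 nM, with a range from 8000 nM to 70000 nM. The expected step of no change at the digits printed from compound 1 to compound 4 (within the scatter) is thus one of no change beyond the usual scatter.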

Compound 4, half-maximal effective concentration: > 10000 nM
Compound 4: no number, only a limit; the forecaster's own chance of this, stated with the estimate: 25%; the middle value is on the limit's open side.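

In this assay compound 4 gives only a limit, > 10000 nM, and not a number. The step between compound 1 and compound 4 therefore cannot be read in size or direction. The compounds shown leave open whether 3-methylphenyl in place of 4-chlorophenyl changes the value in this assay at all.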